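Dropping a ring hydroxyl from a butenolide series

This account rests on a few compounds, and the source may have more. Where it says the series, first, only, none or still open, it means among the compounds named here.

Of the compounds shown here, three of one shared core have been measured in a functional assay on J774.1 cells (Mus musculus), read by LDH release, with a stated time of 1 h, in the presence of a further agent that is not named here; a higher number here means a weaker inhibitor, a lower number a stronger inhibitor. Compound 1 `CC(C)=CCc1cc(/C=C2\OC(=O)C(c3cc4c(cc3O)OC(C)(C)C(O)C4)=C2O)ccc1O` gives 4200 nM. Compound 2 `CC(C)=CCc1cc(C2=C(O)/C(=C/c3ccc4c(c3)CC(O)C(C)(C)O4)OC2=O)c(O)cc1O` gives 2800 nM, and compound 3 `CC(C)=CCc1cc(C2=C(O)/C(=C/c3ccc4c(c3)C[C@H](C(C)(C)O)O4)OC2=O)c(O)cc1O` gives 4900 nM. Within this assay the number for compound 1 sits between those of compound 2 and compound 3, and both gaps fall inside the usual scatter of repeated measurements, so the three cannot be told apart in strength.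

Compound 4 `CC(C)=CCc1cc(/C=C2\OC(=O)C(c3cc4c(cc3O)OC(C)(C)CC4)=C2O)ccc1O` has not yet been measured in this assay. It differs from compound 1 in one place: hydrogen in place of hydroxy on a saturated ring carbon. The hydroxy that leaves sits on a saturated ring carbon of a six-membered non-aromatic ring with one oxygen, part of a fused system of two rings, and a hydrogen takes its place.

Within the data shown here, no pair of measured compounds differs in just one place, so there is no measured step to lean on. The three measured numbers stay close to one another, and the step of a 1.1-fold lower number from compound 1 to compound 4 (0.04 log units; within the scatter) is expected to stay within the scatter, with no clear direction. Compound 4 is therefore estimated at 3800 nM, with a range from 1500 nM to 9500 nM.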

Compound 4, half-maximal inhibitory concentration: 800 nM
Compound 4: middle estimate off by 4.8-fold (0.68 log units), on the high side; measured number below the stated range.
By their numbers in this assay, from the lowest: compound 4; then compounds 2, 1 and 3 (each within the scatter of the next).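

Among the compounds shown, this is the first comparison of two compounds that differ in just one place, and the change has a visible effect. In this assay, hydrogen in place of hydroxy on this saturated ring carbon, two ring bonds from the ring oxygen, gives a 5.3-fold lower number from compound 1 to compound 4 (0.72 log units; beyond the scatter). The hydroxy at this position is therefore not needed for inhibition in this assay, and the inhibitor is stronger without it. Nothing available here explains why the number falls.

On these data alone, it remains open whether the same swap would lower the number for compound 2, which also carries a hydroxy on a saturated ring carbon. Also open, as far as these compounds go, is how other groups on this carbon, such as a methyl, a methoxy or an amine, would compare with hydrogen and hydroxy.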